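This account rests on a few compounds, and the source may have more. Where it says the series, first, only, none or still open, it means among the compounds named here.

Compound 2 `O=S(=O)(NCCCNCC1COc2ccccc2O1)c1cc(C(F)(F)F)cc(C(F)(F)F)c1` has the smallest number recorded so far, although its gap to compound 3 lies within the scatter and only compound 1 sits clearly apart. In a functional assay on A2780 cells (Homo sapiens) for inhibition, read by MTT assay, with a stated time of 72 h (on this read-out higher numbers stand for weaker inhibition of growth and lower numbers for stronger inhibition of growth), compound 2 gives 1500 nM, compound 3 `O=S(=O)(NCCCNCc1ccc(Br)cc1)c1cc(C(F)(F)F)cc(C(F)(F)F)c1` gives 2600 nM, and compound 1 `O=S(=O)(NCCCNCc1ccccc1Cl)c1cc(C(F)(F)F)cc(C(F)(F)F)c1` gives 9300 nM. Compound 4 `COc1ccccc1CNCCCNS(=O)(=O)c1cc(C(F)(F)F)cc(C(F)(F)F)c1` differs from compound 2 in one place: 2-methoxyphenyl in place of 2,3-dihydro-1,4-benzodioxin-2-yl on a saturated chain carbon bound to an amine nitrogen. Among the measured compounds shown here, two steps bear on this: a 6.2-fold lower number from compound 1 to compound 2 (0.79 log units; beyond the scatter) and a 3.6-fold lower number from compound 1 to compound 3 (0.55 log units; beyond the scatter). Both show a substituted phenyl on that chain carbon giving a higher number than the 2,3-dihydro-1,4-benzodioxin-2-yl group, clearly for compound 1 and only within the scatter for compound 3. As 2-methoxyphenyl is again a substituted phenyl, a modest rise is expected, a 2.7-fold higher number from compound 2 to compound 4 (0.43 log units; beyond the scatter). Compound 4 is therefore estimated at 4000 nM, with a range from 1500 nM to 11000 nM.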

Compound 4, concentration for 50% growth inhibition: 1500 nM
Beside the measured number, compound 4's estimate is 2.7-fold (0.43 log units) above it; the range from low to high includes it.
By their numbers in this assay, from the lowest: compounds 2, 4 and 3 (each within the scatter of the next); then compound 1.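

In this assay, the 2-methoxyphenyl group does as well as the 2,3-dihydro-1,4-benzodioxin-2-yl group, with no change at the digits printed from compound 2 to compound 4 (within the scatter), so a substituted phenyl at this chain carbon need not raise the number. The result also stays within the scatter against 4-bromophenyl, with a 1.7-fold lower number from compound 3 to compound 4 (0.24 log units; within the scatter), while methoxy in place of chloro gives a 6.2-fold lower number from compound 1 to compound 4 (0.79 log units; beyond the scatter), so the substituent on the phenyl clearly counts here. Nothing shown explains why these two groups differ. On these data alone, how a hydroxyl or a fluoro group would behave in place of the methoxy remains open. So does the effect of a longer chain.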